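Removing the Ethynyl Group from Compound 2

The compounds below may be only part of what the source reports. "The series", "measured", "known", "first", "only" and "open" are said of these compounds alone.

Of the compounds shown here, three built on a shared core have been tested in a functional assay on A549 cells (Homo sapiens) for cytotoxicity, read by MTT assay, with a stated time of 72 h; a higher number here means a weaker inhibitor, a lower number a stronger inhibitor. Compound 1 `Cc1oc2ncnc(Nc3cccc(Br)c3)c2c1C(=O)O` gives 43000 nM, and compound 3 `Cc1cccc(Nc2ncnc3oc(C)c(CO)c23)c1` gives 24000 nM, two values within the usual scatter of each other. Compound 2 `C#Cc1cccc(Nc2ncnc3oc(C)c(C(=O)OCC)c23)c1` gives > 1000000 nM, which is a limit of the assay and not a number. It is the only one of the three without a measured number.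

Compound 4 `CCOC(=O)c1c(C)oc2ncnc(Nc3ccccc3)c12` keeps everything else in compound 2 but carries hydrogen in place of ethynyl on an aromatic carbon, meta to a large group (hydrogen in place of ethynyl on an aromatic carbon). For the measured compounds named here, no measured pair isolates this change, so there is no direct guide to its size. A modest shift towards stronger inhibition is expected in this assay, and another limit is quite possible. That expectation starts from compound 2 with its > 1000000 nM, again only a limit. The expected change is an at least 2.5-fold lower number from compound 2 to compound 4 (0.39 log units; beyond the scatter). The estimate for compound 4 is 400000 nM, with an expected range from 80000 nM to 1000000 nM.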

Compound 4, half-maximal inhibitory concentration: > 1000000 nM
Compound 4: only a limit was reported; the forecaster's own chance of this, stated with the estimate: 50%; middle value at least 2.5-fold (0.39 log units) from the limit.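

Compound 4 gives > 1000000 nM which is a limit of the assay and not a number. For the compounds shown here, compound 2 also stands only at a limit, so no step between compound 2 and compound 4 can be read: the limit of > 1000000 nM in this assay, at which 2 of the 4 values shown sit. The compounds shown leave open how far hydrogen in place of ethynyl shifts the value.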